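The source may hold more compounds than are shown below. What is called first, only, known or untested is meant among the compounds shown, and "the series" means these compounds.

Compound 1, `CCN(CCC#N)c1nc(C)nc2c(-c3c(C)cc(OC)cc3OC)c(C)nn12`, gives 2.48 nM in an assay on cell membranes for displacement of a labelled ligand from corticotropin-releasing factor receptor 1 (Rattus norvegicus); a lower number here means a stronger inhibitor, a higher number a weaker inhibitor. Among the three measured compounds it carries the highest number, yet both others sit within the usual scatter of it. Compound 2, `CCC(CC)Nc1nc(C)nc2c(-c3cc(F)c(OC)cc3C)c(C)nn12`, gives 1.9 nM in this assay, and compound 3, `CCN(CC)c1nc(C)nc2c(-c3cc(F)c(OC)cc3Cl)c(C)nn12`, gives 1.64 nM. These three also differ from one another in the substituted phenyl ring on the shared core, so none of their gaps can be traced to a single change.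

Compound 4, `COc1cc(C)c(-c2c(C)nn3c(NC4CCC4)nc(C)nc23)c(OC)c1`, has not yet been measured in this assay. It differs from compound 1 in one place: cyclobutylamino in place of (2-cyanoethyl)(ethyl)amino on an aromatic carbon. The three measured compounds carry three different amino groups at this place on the core and still fall within the scatter of one another, so the swap to cyclobutylamino is expected to move the number little, with no step beyond the scatter in either direction.

The step this estimate means, a 1.1-fold lower number from compound 1 to compound 4 (0.05 log units; within the scatter), is expected to be small. Compound 4 is therefore expected to give about 2.2 nM in this assay, within a range from 0.8 nM to 6 nM.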

Compound 4, half-maximal inhibitory concentration: 17.4 nM
Compound 4: the middle estimate sits 7.9-fold (0.90 log units) below what was measured; measured number above the stated range.
By their numbers in this assay, from the lowest: compounds 3, 2 and 1 (each within the scatter of the next); then compound 4.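

Swapping (2-cyanoethyl)(ethyl)amino for cyclobutylamino on this aromatic carbon gives a 7.0-fold higher number from compound 1 to compound 4 (0.85 log units; beyond the scatter) in this assay, so this place on the core does respond to the choice of amino group, which the earlier compounds could not show because they also differ in the substituted phenyl ring. This single swap still changes several things at once: the nitrile leaves, a four-membered carbon ring enters, and the nitrogen gains a hydrogen-bond donor. Nothing measured here shows which of these changes lies behind the step.

Also open, as far as these compounds go, is how much of the step comes from the ring and how much from the loss of the nitrile and the second chain. Ethyl(propyl)amino and cyclopentylamino on the core of compound 1 are among the groups that could help separate these contributions.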